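Three measured analogues and one still to be measured

The compounds below may be only part of what the source reports. "The series", "measured", "known", "first", "only" and "open" are said of these compounds alone.

Compound 1 `COc1ccc(-n2cc(-c3ccccc3)c(-c3ccc4c(c3)NC(=O)CO4)n2)cc1`: 106%
Compound 2 `Cc1ccccc1-n1cc(-c2ccccc2)c(-c2ccc3c(c2)NC(=O)CO3)n1`: 99.4%
Compound 3 `O=C1COc2ccc(-c3nn(-c4ccc(Cl)cc4)cc3-c3ccccc3)cc2N1`: 108%

In a functional assay on MV4-11 cells (Homo sapiens) for cytotoxicity, read by colorimetric assay and MTT assay, with a stated time of 3 days, tested at 1 uM (a lower number here means a stronger effect, a higher number a weaker effect of the compound at the concentration tested), compound 1 gives 106%, the second highest of the three numbers. Its nearest neighbour is compound 3 at 108%, its furthest compound 2 at 99.4%, and both gaps, a number 2 percentage points higher from compound 1 to compound 3 (within the scatter) and a number 6.6 percentage points lower from compound 1 to compound 2 (within the scatter), lie within the scatter.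

Compound 4 `O=C1COc2ccc(-c3nn(-c4cc(Cl)cc(Cl)c4)cc3-c3ccccc3)cc2N1` has not yet been measured in this assay. It differs from compound 1 in one place: 3,5-dichlorophenyl in place of 4-methoxyphenyl on an aromatic nitrogen. All three measured steps exchange the group on that same aromatic nitrogen, and none leaves the scatter: a number 6.6 percentage points lower from compound 1 to compound 2 (within the scatter), a number 2 percentage points higher from compound 1 to compound 3 (within the scatter), a number 8.6 percentage points higher from compound 2 to compound 3 (within the scatter). The closest of them, a number 2 percentage points higher from compound 1 to compound 3 (within the scatter), puts chloro in place of methoxy on an aromatic carbon and moves nothing. No step beyond the scatter is therefore expected in this assay. Compound 4 is estimated at 104%, in a range from 90% to 118%. The expected step of a number 2 percentage points lower from compound 1 to compound 4 (within the scatter) is thus within the scatter.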

Compound 4, a percentage reported as activity, at one concentration (the size of the read-out at that concentration, not a potency): 105%
Compound 4: middle estimate off by 1 percentage points, on the low side; the range from low to high includes it.
By their numbers in this assay, from the lowest: compounds 2, 4, 1 and 3 (each within the scatter of the next).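

In this assay, the 3,5-dichlorophenyl group on the aromatic nitrogen reads like the groups before it, with a number 1 percentage points lower from compound 1 to compound 4 (within the scatter) and a number 3 percentage points lower from compound 3 to compound 4 (within the scatter) and a number 5.6 percentage points higher from compound 2 to compound 4 (within the scatter). So a phenyl group with two chlorines and no hydrogen-bond acceptor, in place of 4-methoxyphenyl with its acceptor, leaves this read-out within the scatter. No evidence bears on this result. The compounds shown leave open whether an amine or a carboxylic acid on this phenyl ring, or a longer chain in its place, would move the read-out. They also leave open whether any change to the other phenyl group would.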